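Replacing bromo with fluoro on the chain carbon of compound 3

The compounds below may be only part of what the source reports. "The series", "measured", "known", "first", "only" and "open" are said of these compounds alone.

Compound 1 `Cc1ccc(S(=O)(=O)OC[C@H]2OC(n3cc(F)c(=O)[nH]c3=O)[C@H](O)[C@@H]2O)cc1` gives 1800 nM in a functional assay on CCRF-CEM cells (Homo sapiens) for inhibition; on this read-out higher numbers stand for weaker inhibition and lower numbers for stronger inhibition. Compound 2 `CS(=O)(=O)OC[C@H]1OC(n2cc(F)c(=O)[nH]c2=O)[C@H](O)[C@@H]1O` gives 660 nM in this assay; the step between them is a 2.7-fold lower number from compound 1 to compound 2 (0.44 log units; beyond the scatter). Compound 3 `O=c1[nH]c(=O)n(C2O[C@H](CBr)[C@@H](O)[C@H]2O)cc1F` gives 3100 nM in this assay, the highest of the three numbers: it lies above compound 2 beyond the scatter, while its gap to compound 1 is within the scatter. The step is a 4.7-fold higher number from compound 2 to compound 3 (0.67 log units; beyond the scatter).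

Compound 4 `O=c1[nH]c(=O)n(C2O[C@H](CF)[C@@H](O)[C@H]2O)cc1F` differs from compound 3 at one place: fluoro in place of bromo on a saturated chain carbon bound to a saturated ring carbon. For the measured compounds named here, no measured step exchanges bromo for fluoro anywhere in the set. The step from compound 2 to compound 3 concerns the same chain carbon and is the nearer precedent; the step from compound 1 to compound 2 concerns a sulfonyl sulfur and bears on it only loosely. Both were modest, and both show that the number in this assay responds to what sits on or near this carbon, without fixing a direction for fluoro. A further modest rise is taken as the more likely outcome, a step within the scatter cannot be ruled out. Compound 4 is therefore expected at 7000 nM, with a range of 1500 nM to 30000 nM, meaning an expected step of a 2.3-fold higher number from compound 3 to compound 4 (0.35 log units; beyond the scatter).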

Compound 4, half-maximal inhibitory concentration: 140000 nM
Beside the measured number, compound 4's estimate is 20-fold (1.30 log units) below it; the measured number lies above the stated range.
By their numbers in this assay, from the lowest: compound 2; then compounds 1 and 3 (each within the scatter of the next); then compound 4.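

In this assay, the group on the saturated chain carbon bound to a saturated ring carbon has a much larger effect than the earlier modest steps showed: fluoro in place of bromo gives a 45-fold higher number from compound 3 to compound 4 (1.65 log units; beyond the scatter), and fluoro in place of (methylsulfonyl)oxy gives a 210-fold higher number from compound 2 to compound 4 (2.33 log units; beyond the scatter). Across compound 2, compound 3 and compound 4, which differ only on this carbon, the numbers rise from (methylsulfonyl)oxy through bromo to fluoro, with each step beyond the scatter. Exchanging one halogen for another at this place is therefore not a conservative change in this series.

No measurement offered here bears on the reason for this large rise. As far as these compounds go, it remains open whether chloro, a hydroxyl or an amine on this carbon would give a number nearer compound 3 or compound 4.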